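A few compounds are considered here, and "the series" means these few. Any claim that something is new, unique, unknown or untested is made for them only; others in the source may bear on it.

Compound 1 `CCCn1cnc2ncnc(N)c21`: > 100000 nM
Compound 2 `CC(C)Cn1cnc2ncnc(N)c21`: > 100000 nM

In an assay on CHO cells for displacement of a labelled ligand from adenosine receptor A1 (Homo sapiens) (a higher number here means a weaker inhibitor, a lower number a stronger inhibitor), compound 1 gives > 100000 nM, which is a limit of the assay and not a number. Compound 2 stands at > 100000 nM, again only a limit. The step that the two limits leave unreadable from compound 1 to compound 2 is therefore unreadable because of the limit of > 100000 nM in this assay, at which 2 of the 2 values shown sit. Compound 3 `Nc1ncnc2ncn(CCO)c12` differs from compound 2 by hydroxymethyl in place of isopropyl on a saturated chain carbon bound to an aromatic nitrogen. Among the measured compounds shown here, no measured step gives a readable size for this change, so compound 3 is expected to remain at the limit as well, with an estimated 150000 nM and a range from 40000 nM to 600000 nM. The expected step is a step that the limit leaves unreadable from compound 2 to compound 3, not readable beyond the limit.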

Compound 3, inhibition constant: > 100000 nM
Compound 3: a limit, no number; the forecaster's own chance of this, stated with the estimate: 85%; the middle value lies beyond the limit too.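

Among the compounds shown here, compound 3 also gives only a limit, so no step among compound 1, compound 2 and compound 3 can be read: the limit of > 100000 nM in this assay, at which 3 of the 3 values shown sit. The compounds shown leave open whether any chain on the shared core gives a readable number in this assay.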